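Cytotoxicity of Compound 4 Expected From Three Limits

The compounds below may be only part of what the source reports. "The series", "measured", "known", "first", "only" and "open" are said of these compounds alone.

Three compounds were measured in an ADME assay on cells (Homo sapiens) for cytotoxicity, read by resazurin assay, with a stated time of 5 days; on this read-out higher numbers stand for lower toxicity in this test and lower numbers for higher toxicity in this test.
Compound 1 `COc1ccc(-c2nc(CNc3cccc(Cl)c3)nc3ccsc23)cn1`: > 50000 nM
Compound 2 `COc1ccc(-c2nc(CSc3cccc(Br)c3)nc3ccsc23)cn1`: > 50000 nM
Compound 3 `COc1ccc(-c2nc(CSc3cc(C)cc(C)c3)nc3ccsc23)cn1`: > 50000 nM

Each of these values is a limit of the assay, not a number. Compound 3 therefore stands only at a limit, and the two other values shown are limits as well; this is the situation of the limit of > 50000 nM in this assay, at which 3 of the 3 values shown sit. The steps a step that the two limits leave unreadable from compound 1 to compound 2, a step that the two limits leave unreadable from compound 1 to compound 3 and a step that the two limits leave unreadable from compound 2 to compound 3 are all left unreadable by the limits, so none of them gives a size.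

Compound 4 `COc1ccc(-c2nc(CCc3cccc(Cl)c3)nc3ccsc23)cn1` differs from compound 3 by 3-chlorobenzyl in place of (3,5-dimethylphenyl)sulfanyl on a saturated chain carbon bound to an aromatic carbon. Within the data shown here, no measured step bears readably on this change, so the expectation rests on the fact that every compound measured so far sits at the limit. The step from compound 3 to compound 4 is expected to be a step that the limit leaves unreadable from compound 3 to compound 4, that is, no readable step. Compound 4 is thus estimated at 80000 nM, with a range from 30000 nM to 300000 nM, and most likely the assay will again report only a limit.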

Compound 4, half-maximal cytotoxic concentration: > 50000 nM
Compound 4 was reported as a limit; the forecaster's own chance of this, stated with the estimate: 85%; the middle value does not contradict the limit.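

Compound 4 stands with compound 1, compound 2 and compound 3 at a limit of this assay and not at a number, so no step among these four compounds can be read: the limit of > 50000 nM in this assay, at which 4 of the 4 values shown sit.

The compounds shown leave open how large any of these changes is, and at what concentration any of the four compounds would show toxicity in this test.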